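The compounds below may be only part of what the source reports. "The series", "measured", "known", "first", "only" and "open" are said of these compounds alone.

Measured compounds:
Compound 1 `Clc1[nH]ccc2ncnc1-2` gives < 5% in a functional assay on EL4 cells (Mus musculus) for inhibition, tested at 100 uM (on this read-out lower numbers stand for less inhibition and higher numbers for more inhibition at the one concentration tested (going by the name of the read-out)), a limit of that assay.
Compound 2 `Nc1nccc2c1ncn2[C@H]1C[C@H](O)[C@@H](CO)O1` gives 89% in this assay.

Compound 2 carries the only actual number shown in this assay; the other value is a limit, (the limit of < 5% in this assay, at which 1 of the 2 values shown sits). Compound 3 `OC[C@H]1O[C@@H](n2cnc3c(Cl)nccc32)C[C@@H]1O` has not yet been measured. It differs from compound 2 by chloro in place of amino on an aromatic carbon. No step between measured compounds is shown, so the size of this change is uncertain. Compound 1, which carries the same chloro, gives < 5% in this assay, a limit of that assay. On that basis compound 3 is expected to lose inhibition, with the step estimated as a number 49 percentage points lower from compound 2 to compound 3 (beyond the scatter). Compound 3 is expected to give 40%, between 5% and 75%.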

Compound 3, a percentage reported as inhibition, at one concentration (the size of the read-out at that concentration, not a potency): < 5%
Compound 3: only a limit was reported; the forecaster's own chance of this, stated with the estimate: 20%; at least 35 percentage points between middle value and limit.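

In this assay, chloro in place of amino on the aromatic carbon next to the ring nitrogen gives a number at least 84 percentage points lower from compound 2 to compound 3 (beyond the scatter), a large step. This is the first single-place change shown, and with the rest of compound 2 kept, the inhibition does not survive the loss of amino at this position. The full size of the step cannot be read, as compound 3 stands at a limit: the limit of < 5% in this assay, at which 2 of the 3 values shown sit.

The compounds shown leave open whether inhibition needs amino itself at this position. A methylamino or hydroxyl group there might keep some of it or none.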